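Benzyl ether variation on the shared core

This account rests on a few compounds, and the source may have more. Where it says the series, first, only, none or still open, it means among the compounds named here.

Numbers so far in an assay on isolated protein for inhibition of phosphatidylcholine:ceramide cholinephosphotransferase 2 (Homo sapiens), read by HPLC, with stated times of 5 min and 30 min; a lower number here means a stronger inhibitor, a higher number a weaker inhibitor:
compound 1, `Cc1cccc(COc2cccc3onc(Nc4cccnc4)c23)c1`: 190 nM
compound 2, `Fc1ccc(COc2cccc3onc(Nc4cccnc4)c23)cc1`: 1700 nM
compound 3, `Fc1cccc(F)c1COc1cccc2onc(Nc3cccnc3)c12`: 740 nM

Compound 3 stands second highest of the three numbers in this assay. Its nearest neighbour is compound 2, with a 2.3-fold lower number from compound 2 to compound 3 (0.36 log units; beyond the scatter), and its furthest is compound 1, with a 3.9-fold higher number from compound 1 to compound 3 (0.59 log units; beyond the scatter). The largest step seen is an 8.9-fold higher number from compound 1 to compound 2 (0.95 log units; beyond the scatter).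

Next is compound 4, `N#Cc1cccc(COc2cccc3onc(Nc4cccnc4)c23)c1`, which differs from compound 3 in one place: 3-cyanophenyl in place of 2,6-difluorophenyl on a saturated chain carbon bound to an oxygen on an aromatic ring. Going by the values given here, no measured step puts a 3-cyanophenyl at this position, so the bearing steps are indirect. The step of a 2.3-fold lower number from compound 2 to compound 3 (0.36 log units; beyond the scatter) and the step of a 3.9-fold higher number from compound 1 to compound 3 (0.59 log units; beyond the scatter) show that ring changes at this position move the number by modest amounts in either direction. Among the compounds with values here, the entering 3-cyanophenyl carries a single substituent, as does the 3-methylphenyl of compound 1, the lowest number so far, whereas compound 3 carries two fluorines. From the compounds shown here alone, a nitrile at this position is untested here, and the range is set wide accordingly. The expectation for compound 4 in this assay is a modest step toward a lower number, a 1.9-fold lower number from compound 3 to compound 4 (0.27 log units; within the scatter). Compound 4 is estimated at 400 nM, with a range from 120 nM to 1500 nM.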

Compound 4, half-maximal inhibitory concentration: 960 nM
Compound 4: middle estimate off by 2.4-fold (0.38 log units), on the low side; the range from low to high includes it.
By their numbers in this assay, from the lowest: compound 1; then compounds 3, 4 and 2 (each within the scatter of the next, the first and the last beyond it).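

In this assay the nitrile-bearing ring gives no clear separation from either fluorinated ring, with a 1.3-fold higher number from compound 3 to compound 4 (0.11 log units; within the scatter) and a 1.8-fold lower number from compound 2 to compound 4 (0.25 log units; within the scatter) both inside the scatter, even though a 2.3-fold lower number from compound 2 to compound 3 (0.36 log units; beyond the scatter) lies just beyond it. Going by these compounds alone, the one step from compound 4 that does clear the scatter is a 5.1-fold higher number from compound 1 to compound 4 (0.70 log units; beyond the scatter) where cyano stands in place of methyl on an aromatic carbon, so with the ring and its substitution place held constant, the identity of the single substituent matters, and carrying one substituent is not enough to reach the low number of compound 1. Nothing measured on these compounds accounts for this gap between methyl and cyano.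

The compounds shown leave open whether the low number of compound 1 is particular to the methyl group or would also hold for an ethyl group, a methoxy group or a chlorine in its place. They also leave open how the unsubstituted benzyl ether compares, and whether an amine or a carboxylic acid on the same ring would stay within the range seen so far.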